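Removing the Benzyl Group From Compound 1

The compounds below may be only part of what the source reports. "The series", "measured", "known", "first", "only" and "open" are said of these compounds alone.

Measured so far:
compound 1 `OC[C@H]1O[C@@H](n2cnc3c(NCc4ccccc4)nccc32)C[C@@H]1O` gives 8%
compound 2 `Clc1[nH]ccc2ncnc1-2` gives a limit of the assay, < 5%
compound 3 `Sc1[nH]ccc2ncnc1-2` gives a limit of the assay, < 5%

Within the data shown here, in a functional assay on EL4 cells (Mus musculus) for inhibition, tested at 100 uM (on this read-out lower numbers stand for less inhibition and higher numbers for more inhibition at the one concentration tested (going by the name of the read-out)), compound 1 is the only compound with a value reported as a number; the other two sit at a limit, as the limit of < 5% in this assay, at which 2 of the 3 values shown sit, shows. Among the measured compounds shown here, the only measured step, a step that the two limits leave unreadable from compound 2 to compound 3, cannot be read from those limits. Compound 4 `Nc1nccc2c1ncn2[C@H]1C[C@H](O)[C@@H](CO)O1` differs from compound 1 by hydrogen in place of benzyl on a nitrogen on an aromatic ring. For the measured compounds named here, no measured step involves a change of this kind, so none bears directly on it. The expected step of a number 3 percentage points lower from compound 1 to compound 4 (within the scatter) is none beyond the scatter. Compound 1 already lies close to the limit, so compound 4 is expected near 5%, within 0% to 14%, with a good chance of a limit instead of a number.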

Compound 4, a percentage reported as inhibition, at one concentration (the size of the read-out at that concentration, not a potency): 89%
Compound 4: the middle estimate sits 84 percentage points below what was measured; the measured number lies above the stated range.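

In this assay hydrogen in place of benzyl on a nitrogen on an aromatic ring gives a number 81 percentage points higher from compound 1 to compound 4 (beyond the scatter) and so shows that this position strongly affects the read-out. With the core and the sugar-like ring unchanged, going from benzylamino to amino alone turns a weak result into strong inhibition at the one concentration tested. Nothing shown explains why this change has so large an effect. The compounds shown leave open whether a methyl group or a longer chain such as propyl on this nitrogen keeps the inhibition. They also leave open whether an acetyl group there would do the same.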